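The compounds below may be only part of what the source reports. "The series", "measured", "known", "first", "only" and "open" are said of these compounds alone.

Series notes, cytotoxicity read in a functional assay on DU-145 cells (Homo sapiens) for cytotoxicity, read by CCK-8 assay and cell counting, with a stated time of 2 days; a lower number here means a stronger inhibitor, a higher number a weaker inhibitor:

compound 1 `Oc1ccc(-c2cc(-c3cccs3)nc(-c3ccccc3Cl)c2)cc1`: 4190 nM
compound 2 `Oc1ccc(-c2cc(-c3ccc(Cl)cc3)nc(-c3cccs3)c2)cc1`: 7660 nM
compound 3 `Oc1ccc(-c2cc(-c3cccc(Cl)c3)nc(-c3cccs3)c2)cc1`: 5740 nM

Compound 3 sits second highest of the three numbers; its nearest neighbour is compound 2, reached as a 1.3-fold lower number from compound 2 to compound 3 (0.13 log units; within the scatter), and the furthest is compound 1, from which compound 3 differs as a 1.4-fold higher number from compound 1 to compound 3 (0.14 log units; within the scatter). The third comparison, a 1.8-fold higher number from compound 1 to compound 2 (0.26 log units; within the scatter), is likewise within the scatter, so the three measured compounds are indistinguishable in this assay.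

Compound 4 `Oc1ccc(-c2cc(-c3cccc(Cl)c3)nc(-c3ccco3)c2)cc1` is the next entry. It differs from compound 3 as furan-2-yl in place of thiophen-2-yl on an aromatic carbon.

Going by the values given here, none of the measured steps touches this exchange: all three concern only the position of the chlorine on the chlorophenyl group, and each of them lies within the scatter. Among the compounds with values here, there is therefore no measured precedent for swapping the five-membered ring, and the only guidance is that the series so far shows no movement beyond the scatter at all.

On that basis the expected step of a 1.0-fold higher number from compound 3 to compound 4 (0.02 log units; within the scatter) is none beyond the scatter, and compound 4 is estimated at 6000 nM, with a range of 2500 nM to 15000 nM to allow for the untested nature of the change.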

Compound 4, half-maximal inhibitory concentration: 5750 nM
For compound 4 the middle estimate is 1.0-fold (0.02 log units) above the measured one, within the range that was stated.
By their numbers in this assay, from the lowest: compounds 1, 3, 4 and 2 (each within the scatter of the next).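

In this assay, going by these compounds alone, the exchange of thiophen-2-yl for furan-2-yl, on the aromatic carbon next to the ring nitrogen, gives a 1.0-fold higher number from compound 3 to compound 4 (0.00 log units; within the scatter) and is the first step at this position rather than in the placement of the chlorine on the chlorophenyl group. Sulfur and oxygen are thus interchangeable here as far as this read-out can tell, at least with a 3-chlorophenyl group and a 4-hydroxyphenyl group on the shared core, and the series still shows no step beyond the scatter. No measurement at hand bears on why the two five-membered aromatic rings cannot be told apart in this assay.

The compounds shown leave open whether furan-2-yl and thiophen-2-yl would also match each other alongside a 2-chlorophenyl or 4-chlorophenyl group, since this exchange is read in a single pair. They also leave open whether a group of another kind at this position, such as an aminomethyl group, a carboxylic acid or a longer alkyl chain, would move the number beyond the scatter.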